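Thiophene in Place of the Piperidine Arm

The source may report more compounds than this note shows. Statements on the series, on what has been measured and on what is new or still open speak of the compounds shown alone.

Within the data shown here, compound 2 `COc1cc2nc(NCCN3CCCCC3)nc(NC3CCCCCC3)c2cc1OC` gives 18% in an in vitro assay on B300-19 cells for displacement of a labelled ligand from C-C chemokine receptor type 4 (Homo sapiens), tested at 1 uM (a lower number here means less inhibition, a higher number more inhibition at the concentration tested (going by the name of the read-out)), the only plain number available for this set. Compound 1 `COc1cc2nc(N3CCC(N4CCCC4)CC3)nc(NCc3ccccc3)c2cc1OC` reaches the limit of < 0% in this assay, a limit rather than a number (the limit of < 0% in this assay, at which 1 of the 2 values shown sits). Compound 3 `COc1cc2nc(NCc3cccs3)nc(NC3CCCCCC3)c2cc1OC` has not yet been measured in this assay. It differs from compound 2 in one place: thiophen-2-yl in place of (piperidin-1-yl)methyl on a saturated chain carbon bound to a nitrogen on an aromatic ring. Among the measured compounds shown here, no measured step covers this change. Compound 3 is expected to lose some inhibition in this assay, an estimated a number 10 percentage points lower from compound 2 to compound 3 (within the scatter). Compound 3 is therefore estimated at 8%, within a range from -5% to 25%.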

Compound 3, a percentage reported as inhibition, at one concentration (the size of the read-out at that concentration, not a potency): < 0%
Compound 3 ended at the assay's limit (the forecaster's own chance of this, stated with the estimate: 30%); at least 8 percentage points between middle value and limit.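

Thiophen-2-yl in place of (piperidin-1-yl)methyl on this saturated chain carbon leaves a number at least 18 percentage points lower from compound 2 to compound 3 (beyond the scatter) in this assay, a sign that the group held here matters to the read-out. Compound 3 gives < 0%, which is a limit and not a number. As far as these compounds go, the full size of the step therefore stays unknown, and the compounds crowd at one end of the scale: the limit of < 0% in this assay, at which 2 of the 3 values shown sit.

From the compounds shown here alone, whether the loss goes with the piperidine ring leaving or the thiophene entering stays open. A morpholin-4-yl group or a longer chain carrying the thiophen-2-yl could separate the two.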